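A few compounds are considered here, and "the series" means these few. Any claim that something is new, unique, unknown or untested is made for them only; others in the source may bear on it.

Compound 1 `O=C(CSc1ncccn1)N/N=c1/scc(-c2ccc(Br)cc2)n1-c1ccccc1` is the starting point. In a functional assay on C6 cells (Rattus norvegicus) for cytotoxicity, read by MTT assay, with a stated time of 24 h, tested at 6 ug/mL (on this read-out lower numbers stand for a stronger effect and higher numbers for a weaker effect at the one concentration tested), compound 1 gives 76.4%, the highest of the three numbers in hand. Compound 3 `O=C(CSc1nnnn1-c1ccccc1)N/N=c1/scc(-c2ccc(F)cc2)n1-c1ccccc1` gives 74.9%, which lies within the scatter of compound 1, whereas compound 2 `O=C(CSc1nnnn1-c1ccccc1)N/N=c1/scc(-c2ccccc2)n1-c1ccccc1` gives 52.1%, a number beyond the scatter below compound 1. Within the data shown here, the only step between two compounds that differ in one place is a number 22.8 percentage points higher from compound 2 to compound 3 (beyond the scatter), a fluoro in place of hydrogen on an aromatic carbon.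

Compound 4 `Cc1ccc(-c2cs/c(=N/NC(=O)CSc3ncccn3)n2-c2ccccc2)cc1` differs from compound 1 in one place: methyl in place of bromo on an aromatic carbon. The exchange sits on the same ring as the change from compound 2 to compound 3, yet it replaces one group with another rather than adding a group where hydrogen stood, so a number 22.8 percentage points higher from compound 2 to compound 3 (beyond the scatter) bears on it only loosely. Among the measured compounds shown here, no measured pair shows bromo against methyl directly, and the two compounds that carry different groups on that ring while sharing the rest of the ring, compound 1 and compound 3, give numbers within the scatter of each other. On this basis compound 4 is expected to stay close to compound 1, with the step of a number 4.4 percentage points lower from compound 1 to compound 4 (within the scatter) expected to fall within the scatter. Compound 4 is therefore estimated at 72%, with a range from 56% to 88%.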

Compound 4, a percentage reported as activity, at one concentration (the size of the read-out at that concentration, not a potency): 93.2%
Estimate against measurement, compound 4: 21.2 percentage points below; the whole stated range lies below it.
By their numbers in this assay, from the lowest: compound 2; then compounds 3 and 1 (each within the scatter of the next); then compound 4.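

In this assay, the exchange of 4-bromophenyl for 4-methylphenyl gives a number 16.8 percentage points higher from compound 1 to compound 4 (beyond the scatter), which shows that this position responds when one substituent replaces another, not only when a group replaces hydrogen, and that on this read-out the methyl compound has the weaker effect. The earlier step, a number 22.8 percentage points higher from compound 2 to compound 3 (beyond the scatter), came from a different pair of compounds and showed only fluoro replacing hydrogen; the new step moves in the same direction, so both changes measured on this ring give higher numbers. Bromo and methyl match in the counts of heavy atoms, hydrogen-bond donors and acceptors and in having no net charge, so those counts do not separate the two groups, and nothing measured here accounts for the step.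

The compounds shown leave open how a methoxy group, an amine or a carboxylic acid would read at this place on the core of compound 1. They also leave open whether methyl in place of bromo would give a step of similar size in the series of compound 2, which differs from compound 1 at the other end of the molecule.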